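Pyridinyl in Place of Dimethylaminophenyl: Cytotoxicity Expectation

This account rests on a few compounds, and the source may have more. Where it says the series, first, only, none or still open, it means among the compounds named here.

Compound 1 `COc1ccc([C@H]2CC(=O)N(c3cccc(N(C)C)c3)C2)cc1OC1CCCC1` sits at a limit of the assay in a functional assay on HEK293 cells (Homo sapiens) for cytotoxicity (on this read-out higher numbers stand for lower toxicity in this test and lower numbers for higher toxicity in this test), with > 10000 nM.
Compound 2 `COc1ccc([C@H]2CC(=O)N(c3ccc(C)c(N)c3)C2)cc1OC1CCCC1` likewise reaches only a limit, > 10000 nM.
Compound 3 `COc1ccc([C@H]2CC(=O)N(c3ccc(C(F)(F)F)cc3)C2)cc1OC1CCCC1` also stops at a limit, > 10000 nM.

Compound 1 therefore stands at the ceiling of this test, and the same is true of all three measured values, as the limit of > 10000 nM in this assay, at which 3 of the 3 values shown sit, shows. The steps among them, a step that the two limits leave unreadable from compound 1 to compound 2, a step that the two limits leave unreadable from compound 1 to compound 3 and a step that the two limits leave unreadable from compound 2 to compound 3, cannot be read in size, since each ends at a limit on both sides.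

Among the measured compounds shown here, compound 4 `COc1ccc([C@H]2CC(=O)N(c3ccccn3)C2)cc1OC1CCCC1` differs from compound 1 by pyridin-2-yl in place of 3-(dimethylamino)phenyl on an amide-type nitrogen in a ring, the only change being on an amide-type nitrogen in a ring of the shared core. Every change so far at that same position has left the read-out at the limit, so no step beyond the scatter is expected here either. Compound 4 is expected to give about 10000 nM, with a range from 5000 nM to 20000 nM. The estimated step of a number no higher from compound 1 to compound 4 (the limit leaves the size open) is expected to be none beyond the scatter, with a limit rather than a number the likeliest outcome.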

Compound 4, half-maximal cytotoxic concentration: > 10000 nM
Compound 4 gave a limit, no number (the forecaster's own chance of this, stated with the estimate: 80%); the middle value lies on the limit itself.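

Compound 4 gives a limit and not a number, as do compound 1, compound 2 and compound 3, so none of the steps to compound 4 can be read: the limit of > 10000 nM in this assay, at which 4 of the 4 values shown sit.

The compounds shown leave open whether any group on the amide-type nitrogen in a ring would change the read-out in this assay.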